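Dichlorophenyl regioisomers on the allyl diketopiperazine scaffold

The source may report more compounds than this note shows. Statements on the series, on what has been measured and on what is new or still open speak of the compounds shown alone.

Measured so far in a functional assay on K562 cells (Homo sapiens) for cytotoxicity, read by CCK-8 assay, with a stated time of 72 h; on this read-out lower numbers stand for stronger inhibition and higher numbers for weaker inhibition:
compound 1 `C=CCn1c(=O)/c(=C\c2cc(F)ccc2C)[nH]c(=O)/c1=C\c1ccccc1OC` — 1800 nM
compound 2 `C=CCn1c(=O)/c(=C\c2ccccc2C(F)(F)F)[nH]c(=O)/c1=C\c1ccccc1OC` — 2700 nM
compound 3 `C=CCn1c(=O)/c(=C\c2ccc(Cl)c(Cl)c2)[nH]c(=O)/c1=C\c1ccccc1OC` — "not active" (no number reported)

Compound 3 stands apart from the other two: in this assay it carries no single number and is reported only as not active, whereas compound 1 and compound 2 both give measured values. Compound 4 `C=CCn1c(=O)/c(=C\c2cccc(Cl)c2Cl)[nH]c(=O)/c1=C\c1ccccc1OC` differs from compound 3 by 2,3-dichlorophenyl in place of 3,4-dichlorophenyl on a double-bonded chain carbon bound to an aromatic carbon. Among the compounds with values here, the only measured step, a 1.5-fold higher number from compound 1 to compound 2 (0.18 log units; within the scatter), changes the same aryl group but neither of its two groups is a dichlorophenyl, so it bears on compound 4 only loosely. It shows that exchanging one aryl for another at this position can leave the number within the scatter; compound 3 shows it can also abolish a measurable value. With no number for compound 3, the direction cannot be computed. Compound 4 is expected to fall near 5000 nM, within 1500 nM to 30000 nM, with a fair chance that this assay again reports only a limit.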

Compound 4, half-maximal inhibitory concentration: 900 nM
Estimate against measurement, compound 4: 5.6-fold (0.74 log units) above; measured number outside the range, below it.
By their numbers in this assay, from the lowest: compounds 4, 1 and 2 (each within the scatter of the next, the first and the last beyond it).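

In this assay, within the data shown here, the same two chlorines separate a measured value from none: as 2,3-dichlorophenyl compound 4 gives 900 nM and as 3,4-dichlorophenyl compound 3 gives "not active" (no number reported) so no step between these two can be read. Among the measured aryl groups, a 3.0-fold lower number from compound 2 to compound 4 (0.48 log units; beyond the scatter) is beyond the scatter, while a 2.0-fold lower number from compound 1 to compound 4 (0.30 log units; within the scatter) is within it. No measurement here accounts for the difference between the two dichlorophenyl groups.

Open, on these data alone, is whether a single chlorine, an amine or a carboxylic acid on this aryl ring keeps a measured value. Also open, as far as these compounds go, is how a longer chain in place of the allyl group would read.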